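Removing one trifluoromethyl group from compound 1

This account rests on a few compounds, and the source may have more. Where it says the series, first, only, none or still open, it means among the compounds named here.

Compound 1 `Cc1cc(=O)oc2cc(OCC(=O)c3cc(C(F)(F)F)cc(C(F)(F)F)c3)ccc12` 930 nM
Compound 2 `Cc1cc(=O)oc2cc(OCC(=O)c3ccc(C(C)(C)C)cc3)ccc12` 22300 nM
Compound 3 `Cc1cc(=O)oc2cc(OCC(=O)c3ccccc3C(F)(F)F)ccc12` 20400 nM

These three compounds share a core and differ in the substituents on the aromatic ring of the side chain. They were tested in a functional assay on CWR22R cells (Homo sapiens) for antiproliferative activity, with a stated time of 96 h (on this read-out higher numbers stand for weaker inhibition and lower numbers for stronger inhibition), and compound 1 gives the lowest number of the set (930 nM). Its lead is beyond the scatter over both of the others, so it is the most potent of the three. Compound 2 (22300 nM) and compound 3 (20400 nM) lie within the scatter of each other.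

Within the data shown here, the next compound to be considered is compound 4 `Cc1cc(=O)oc2cc(OCC(=O)c3cccc(C(F)(F)F)c3)ccc12`, which has no measurement yet. It has hydrogen in place of trifluoromethyl on an aromatic carbon, and it keeps the other trifluoromethyl group of compound 1.

Among the measured compounds shown here, no measured pair isolates this change, so any expectation is tentative. The closest guide is compound 3, which also bears a lone trifluoromethyl group and reads far higher (20400 nM). A loss of potency beyond the scatter is therefore expected, and the estimated step is a 9.7-fold higher number from compound 1 to compound 4 (0.99 log units; beyond the scatter). The estimated value for compound 4 is 9000 nM (expected range 2500 nM to 30000 nM).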

Compound 4, half-maximal inhibitory concentration: > 100000 nM
Compound 4 gave a limit, no number; the forecaster's own chance of this, stated with the estimate: 10%; middle value at least 11-fold (1.04 log units) from the limit.
By their numbers in this assay, from the lowest: compound 1; then compounds 3 and 2 (each within the scatter of the next). At a limit, above all of these: compound 4.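

In this assay, among these compounds, compound 1 and compound 4 form the first pair that isolates a single change, and hydrogen in place of trifluoromethyl on this aromatic carbon gives an at least 100-fold higher number from compound 1 to compound 4 (2.03 log units; beyond the scatter). For compound 4, the reading of > 100000 nM is a limit of the assay and not a number. The earlier compounds shown here could not show that this one trifluoromethyl group carries so much of the activity of compound 1, as the remaining trifluoromethyl group alone does not keep compound 4 on the measured scale, and the step is therefore a minimum: the limit of > 100000 nM in this assay, at which 1 of the 4 values shown sits.

From the compounds shown here alone, what a chlorine atom, a methyl group, a methoxy group or a nitrile would do on this same aromatic carbon remains open, so the pair cannot say whether trifluoromethyl in particular is needed there or whether another group would serve. Also open, going by these compounds, is the true distance between the two compounds, and whether the loss seen here would appear on any other read-out of activity.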